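Adding a methylamino group to the most potent bis-amine scaffold

The source may report more compounds than this note shows. Statements on the series, on what has been measured and on what is new or still open speak of the compounds shown alone.

Measured compounds:
- Compound 1, `O=C(NCCCNC1CCCCC1)c1ccc(C(=O)NCCCNC2CCCCC2)cc1`: 1700 nM
- Compound 2, `c1cc(CNCCCNC2CCCCC2)cc(CNCCCNC2CCCCC2)c1`: 156 nM
- Compound 3, `O=[N+]([O-])c1cc(CNCCCNC2CCCCC2)ccc1CNCCCNC1CCCCC1`: 354 nM

Of the compounds shown here, three have been tested in an assay on CHO cells for displacement of a labelled ligand from C-X-C chemokine receptor type 4 (Homo sapiens), with a stated time of 40 min; a higher number here means a weaker inhibitor, a lower number a stronger inhibitor. Compound 1 carries two amide linkers on its core and gives 1700 nM. Compound 2 replaces those amides with benzylic amines and gives 156 nM, the lowest number of the three. Compound 3 carries a nitro group on a differently arranged core and gives 354 nM. Compound 2 stands below compound 3 by a margin beyond the scatter and below compound 1 by a much larger margin, so it is the strongest inhibitor among the measured set.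

Compound 4, `CNc1cc(CNCCCNC2CCCCC2)cc(CNCCCNC2CCCCC2)c1`, is not yet measured. It differs from compound 2 by methylamino in place of hydrogen on an aromatic carbon. For the measured compounds named here, no measured pair shows this particular change, so its effect can only be anticipated. Since the change adds a small substituent to the ring of compound 2 while leaving both amine side chains intact, a step from compound 2 to compound 4 of modest size is expected, most likely within the scatter or a slight weakening: a 1.4-fold higher number from compound 2 to compound 4 (0.15 log units; within the scatter). Compound 4 is therefore estimated to give 220 nM in this assay, with a range from 80 nM to 600 nM.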

Compound 4, half-maximal inhibitory concentration: 67.6 nM
The estimate for compound 4 lay 3.3-fold (0.51 log units) above the measured number; the measured number lies below the stated range.
By their numbers in this assay, from the lowest: compound 4; then compound 2; then compound 3; then compound 1.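

In this assay, methylamino in place of hydrogen on an aromatic carbon, meta to two large groups, gives a 2.3-fold lower number from compound 2 to compound 4 (0.36 log units; beyond the scatter), so a substituent at this place on the shared core is accepted and the number moves down rather than up. For the compounds shown here, the earlier compounds offered no pair differing in one place, so this is the first reading of a single change on this ring; compound 3, with its nitro group on a differently arranged core, cannot be set against it. Nothing shown here gives a reason for this step.

As far as these compounds go, it remains open whether the lower number depends on the nitrogen or on its methyl, which a plain amino group, a dimethylamino group or a methoxy group at the same place would begin to separate, and whether larger groups, such as a longer alkylamino chain or a carboxylic acid, would be accepted there as well. From the compounds shown here alone, it is also open whether methylamino would give a step of similar size on the amide-linked core of compound 1.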